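This account rests on a few compounds, and the source may have more. Where it says the series, first, only, none or still open, it means among the compounds named here.

Compound 2 `COc1ccc(-c2cc(C(=O)Nc3nc4ccc(F)cc4s3)nc3cc(-c4ccccc4)nn23)cc1` and compound 1 `COc1cc(-c2cc(C(=O)Nc3nc4ccc(Cl)cc4s3)nc3cc(-c4ccccc4)nn23)cc(OC)c1OC` both show weak activity in a functional assay on HeLa cells (Homo sapiens) for cytotoxicity, read by MTT assay, with a stated time of 48 h; on this read-out higher numbers stand for weaker inhibition and lower numbers for stronger inhibition. In this assay compound 2 gives 41700 nM, the higher of the two numbers, while compound 1 gives 22400 nM, a difference that sits within the scatter. Compound 3 `COc1cc(-c2cc(C(=O)Nc3nc4ccc(F)cc4s3)nc3cc(-c4ccccc4)nn23)cc(OC)c1OC` is not yet measured; it carries 3,4,5-trimethoxyphenyl in place of 4-methoxyphenyl on an aromatic carbon. Within the data shown here, no single-change step between measured compounds is available, so any expected shift rests on compound 1, which shares the trimethoxyphenyl group. The step from compound 2 to compound 3 is expected to be small, a 1.7-fold lower number from compound 2 to compound 3 (0.22 log units; within the scatter), likely not beyond the scatter. Compound 3 is estimated at 25000 nM, with a range from 10000 nM to 60000 nM.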

Compound 3, half-maximal inhibitory concentration: 25100 nM
Compound 3: middle estimate off by 1.0-fold (0.00 log units), on the low side; the range from low to high includes it.
By their numbers in this assay, from the lowest: compounds 1, 3 and 2 (each within the scatter of the next).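

In this assay the change from 4-methoxyphenyl to 3,4,5-trimethoxyphenyl gives a 1.7-fold lower number from compound 2 to compound 3 (0.22 log units; within the scatter) and so leaves the number within the scatter at this position. Fluoro in place of chloro on the other side of the molecule gives a 1.1-fold higher number from compound 1 to compound 3 (0.05 log units; within the scatter) and is just as small a step. No measurement is available to explain these small steps.

Still open, as far as these compounds go, is whether an amine or a carboxylic acid on this phenyl ring, in place of the methoxy groups, would move the number beyond the scatter.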